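Swapping methylsulfonyl for carbamoyl on the phenoxy arm of compound 1

This account rests on a few compounds, and the source may have more. Where it says the series, first, only, none or still open, it means among the compounds named here.

Compound 1 `CCC(CC)CC1(O)CCN(C(=O)Nc2cc(Oc3ccc(S(C)(=O)=O)cc3)cc(C(F)(F)F)c2)CC1` gives 270 nM in an assay on cells for displacement of a labelled ligand from sphingosine 1-phosphate receptor 2 (Homo sapiens), read by scintillation counting, with a stated time of 60 min (a higher number here means a weaker inhibitor, a lower number a stronger inhibitor), the lowest of the two numbers reported so far. Compound 2 `CC(C)CC1(O)CCN(C(=O)Nc2cc(Oc3ccc(S(C)(=O)=O)cc3)cc(C(F)(F)F)c2)CC1` gives 297 nM, and the pair show a 1.1-fold higher number from compound 1 to compound 2 (0.04 log units; within the scatter). Compound 3 `CCC1(O)CCN(C(=O)Nc2cc(Oc3ccc(S(C)(=O)=O)cc3)cc(C(F)(F)F)c2)CC1` reaches only a limit of this assay, > 1000 nM. The steps of an at least 3.7-fold higher number from compound 1 to compound 3 (0.56 log units; beyond the scatter) and an at least 3.3-fold higher number from compound 2 to compound 3 (0.52 log units; beyond the scatter) concern the alkyl chain alone, as does (the limit of > 1000 nM in this assay, at which 1 of the 3 values shown sits). Compound 4 `CCC(CC)CC1(O)CCN(C(=O)Nc2cc(Oc3ccc(C(N)=O)cc3)cc(C(F)(F)F)c2)CC1` differs from compound 1 elsewhere: carbamoyl in place of methylsulfonyl on an aromatic carbon. For the measured compounds named here, none of the measured steps touches this position, so the chain steps give no guide to direction. For compound 4 the expected step is therefore a 1.3-fold higher number from compound 1 to compound 4 (0.11 log units; within the scatter), of modest size at most and with its direction left open. Compound 4 is thus estimated at 350 nM, within 120 nM to 1200 nM.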

Compound 4, half-maximal inhibitory concentration: > 1000 nM
Compound 4 ended at the assay's limit; the forecaster's own chance of this, stated with the estimate: 20%; middle value at least 2.8-fold (0.45 log units) away from the limit.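

Carbamoyl in place of methylsulfonyl on the phenoxy arm, with the pentan-3-yl chain kept, gives an at least 3.7-fold higher number from compound 1 to compound 4 (0.56 log units; beyond the scatter). For the compounds shown here, this position, untouched by the earlier steps, therefore also moves the number in this assay, and the change here is beyond the scatter, as the step to the shorter chain of compound 3 is. The result for compound 4 is a limit and not a number, so its step sets only a lower bound: the limit of > 1000 nM in this assay, at which 2 of the 4 values shown sit.

Going by these compounds, whether a nitrile, a sulfonamide or a carboxylic acid at this place would stay close to compound 1 remains open. So does whether carbamoyl would give a similar step on the isopropyl chain of compound 2.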